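Swapping a ring on a shared core: expecting compound 4

A few compounds are considered here, and "the series" means these few. Any claim that something is new, unique, unknown or untested is made for them only; others in the source may bear on it.

Compound 2 `O=C1NC(O)(CCn2cc(C3=CCCCC3)nn2)C(OCc2ccccc2)=C1OCc1ccccc1` holds the lower of the two numbers given in a functional assay on MDA-MB-231 cells (Homo sapiens) for antiproliferative activity, read by MTT assay, with a stated time of 24 h (on this read-out higher numbers stand for weaker inhibition and lower numbers for stronger inhibition), where compound 2 gives 13100 nM. Compound 1 `O=C1O/C(=C\Cn2cc(Cc3ccccc3)nn2)C(OCc2ccccc2)=C1OCc1ccccc1`, the nearest of the measured compounds, gives 29200 nM in this assay, a gap beyond the scatter. Compound 3 `Cc1ccc(-c2cn(C/C=C3\OC(=O)C(OCc4ccccc4)=C3OCc3ccccc3)nn2)cc1` reaches only a limit in this assay, > 100000 nM. Compound 4 `CC(C)(C)c1ccc(-c2cn(CCC3(O)NC(=O)C(OCc4ccccc4)=C3OCc3ccccc3)nn2)cc1` differs from compound 2 by one change: 4-(tert-butyl)phenyl in place of cyclohex-1-en-1-yl on an aromatic carbon. Among the compounds with values here, the only measured step at the same place runs from compound 1 to compound 3, where an at least 3.4-fold higher number from compound 1 to compound 3 (0.53 log units; beyond the scatter); its true size is known only from below, since compound 3 sits at the limit of > 100000 nM in this assay, at which 1 of the 3 values shown sits. That step also placed an aromatic ring directly on the five-membered ring, in place of benzyl, and inhibition became weaker. By analogy, a modest weakening is expected for compound 4, a 2.3-fold higher number from compound 2 to compound 4 (0.36 log units; beyond the scatter). The estimate for compound 4 in this assay is therefore 30000 nM, with a range from 10000 nM to 100000 nM.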

Compound 4, half-maximal inhibitory concentration: > 100000 nM
Compound 4: no number, only a limit; the forecaster's own chance of this, stated with the estimate: 20%; at least 3.3-fold (0.52 log units) between middle value and limit.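

On the core of compound 2, putting 4-(tert-butyl)phenyl in place of cyclohex-1-en-1-yl on this aromatic carbon gives an at least 7.6-fold higher number from compound 2 to compound 4 (0.88 log units; beyond the scatter) in this assay. The weakening first seen on the core of compound 1 therefore also appears on a second core, and the two compounds with a substituted benzene ring directly at this place, compound 3 and compound 4, both end at the same limit, with no compound shown going against this. The value of compound 4 is a limit and not a number, so the size of this step is known only from below: the limit of > 100000 nM in this assay, at which 2 of the 4 values shown sit.

With both values at a limit, 4-methylphenyl and 4-(tert-butyl)phenyl cannot be ranked against each other. Also open, on these data alone, is how a plain phenyl, a cyclohexyl, or a phenyl carrying an amine or a carboxylic acid would behave at this place.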